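A few compounds are considered here, and "the series" means these few. Any claim that something is new, unique, unknown or untested is made for them only; others in the source may bear on it.

Measured so far in a functional assay on isolated protein for inhibition of Glucose-dependent insulinotropic receptor (Homo sapiens), read by HTRF and cAMP accumulation; on this read-out lower numbers stand for an effect already at smaller amounts and higher numbers for an effect only at larger amounts of compound:
compound 1, `Cc1nc(S(C)(=O)=O)ccc1Oc1ncnc(OC2CCN(C(=O)O[C@H](C)CF)CC2)c1F`, 196 nM
compound 2, `Cc1nc(S(C)(=O)=O)ccc1Oc1ncnc(OC2CCN(C(=O)OC3(C(F)(F)F)COC3)CC2)c1F`, 29.3 nM
compound 3, `Cc1nc(S(C)(=O)=O)ccc1Oc1ncnc(OC2CCN(C(=O)C(C)(C)F)CC2)c1F`, 76.3 nM

Compound 3 stands second highest of the three numbers in this assay. The smaller gap is the step of a 2.6-fold lower number from compound 1 to compound 3 (0.41 log units; beyond the scatter); the larger one is the step of a 2.6-fold higher number from compound 2 to compound 3 (0.42 log units; beyond the scatter). Between the two carbamates the step of a 6.7-fold lower number from compound 1 to compound 2 (0.83 log units; beyond the scatter) was the largest change seen so far.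

Compound 4, `CCC(F)(F)C(=O)N1CCC(Oc2ncnc(Oc3ccc(S(C)(=O)=O)nc3C)c2F)CC1`, has not yet been measured in this assay. It differs from compound 3 in one place: 1,1-difluoropropyl in place of 1-fluoro-1-methylethyl on a carbonyl carbon. Within the data shown here, none of the measured steps bears directly on this exchange. Among the measured compounds shown here, the step of a 6.7-fold lower number from compound 1 to compound 2 (0.83 log units; beyond the scatter) altered the group on the carbamate oxygen, and the steps of a 2.6-fold lower number from compound 1 to compound 3 (0.41 log units; beyond the scatter) and a 2.6-fold higher number from compound 2 to compound 3 (0.42 log units; beyond the scatter) replaced a carbamate by an amide; no pair of measured compounds differs only in the chain carried by an amide carbonyl. What can be said is that the carbamate-to-amide exchange and the change between the two carbamates were both modest, so the expected step here is likewise modest, a 1.3-fold lower number from compound 3 to compound 4 (0.10 log units; within the scatter), with no firm direction. Compound 4 is therefore estimated at 60 nM, with a range from 25 nM to 150 nM.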

Compound 4, half-maximal effective concentration: 17.4 nM
Compound 4: middle estimate off by 3.4-fold (0.54 log units), on the high side, and the stated range ends above it.
By their numbers in this assay, from the lowest: compounds 4 and 2 (each within the scatter of the next); then compound 3; then compound 1.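

In this assay, among these compounds, the step of a 4.4-fold lower number from compound 3 to compound 4 (0.64 log units; beyond the scatter) is the first reading of a change in the chain itself on a carbonyl carbon whose other neighbours are an amide-type nitrogen in a ring, and it shows that this place responds to that chain and not only to the choice between carbamate and amide. The step of a 1.7-fold lower number from compound 2 to compound 4 (0.23 log units; within the scatter) lies within the scatter, so this amide and the carbamate compound 2 cannot be told apart, while the step of an 11-fold lower number from compound 1 to compound 4 (1.05 log units; beyond the scatter) is the largest among the compounds shown and the only one classed as large. No measurement shown gives a reason for the gain seen with 1,1-difluoropropyl.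

The exchange alters the carbon count of the chain's arrangement and the fluorine count together, so the compounds shown cannot separate the two contributions. From the compounds shown here alone, how a plain propyl, a 1,1-difluoroethyl or a longer 1,1-difluorobutyl chain on the same carbonyl carbon would read, and whether the same chain would behave alike on a carbamate, remains open.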